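Swapping the benzyloxy ring: from compound 3 to compound 4

This account rests on a few compounds, and the source may have more. Where it says the series, first, only, none or still open, it means among the compounds named here.

Measured so far in a functional assay on Huh-7 cells (Homo sapiens) for antiproliferative activity, read by sulforhodamine B assay, with a stated time of 72 h; on this read-out lower numbers stand for stronger inhibition and higher numbers for weaker inhibition:
compound 1 `Cc1ccccc1COc1ccc(-c2cc(CN3CCN(Cc4ccc(C(F)(F)F)cc4)CC3)no2)cc1`, 1200 nM
compound 2 `Cc1ccc(COc2ccc(-c3cc(CN4CCN(Cc5ccc(C(F)(F)F)cc5)CC4)no3)cc2)cc1`, 1500 nM
compound 3 `Fc1ccccc1COc1ccc(-c2cc(CN3CCN(Cc4ccc(C(F)(F)F)cc4)CC3)no2)cc1`, 1500 nM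

Compound 3 stands level with compound 2 at the digits given, the two together holding the highest numbers of the three; toward compound 1 the step is a 1.3-fold higher number from compound 1 to compound 3 (0.10 log units; within the scatter). The new compound, compound 4 `COc1cccc(COc2ccc(-c3cc(CN4CCN(Cc5ccc(C(F)(F)F)cc5)CC4)no3)cc2)c1`, carries 3-methoxyphenyl in place of 2-fluorophenyl on a saturated chain carbon bound to an oxygen on an aromatic ring. Two earlier steps touch this same benzyloxy ring: a 1.3-fold higher number from compound 1 to compound 2 (0.10 log units; within the scatter) and no change at the digits printed from compound 2 to compound 3 (within the scatter). Both sit within the scatter, so for compound 4 no shift beyond the scatter is expected, no change at the digits printed from compound 3 to compound 4 (within the scatter). Compound 4 is therefore estimated at 1500 nM, within a range from 700 nM to 3200 nM.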

Compound 4, half-maximal inhibitory concentration: 800 nM
The estimate for compound 4 lay 1.9-fold (0.27 log units) above the measured number; the measured number falls inside the stated range.
By their numbers in this assay, from the lowest: compounds 4, 1, 2 and 3 (each within the scatter of the next).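

In this assay, 3-methoxyphenyl, which unlike 2-fluorophenyl counts a hydrogen-bond acceptor, still gives only steps within the scatter: a 1.9-fold lower number from compound 3 to compound 4 (0.27 log units; within the scatter), a 1.9-fold lower number from compound 2 to compound 4 (0.27 log units; within the scatter) and a 1.5-fold lower number from compound 1 to compound 4 (0.18 log units; within the scatter). The four aryl groups at this position therefore cannot be told apart, and the added acceptor produces no shift beyond the scatter. Nothing available offers an explanation for this result. Going by these compounds, whether an amine or a carboxylic acid on this ring would move the number beyond the scatter remains open. So does whether a longer chain in place of the benzyl link would do so.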